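Moving the trifluoromethoxy group: notes toward compound 4

A few compounds are considered here, and "the series" means these few. Any claim that something is new, unique, unknown or untested is made for them only; others in the source may bear on it.

Measured so far:
- compound 1 `Cc1cnc(Nc2ccc(N3C[C@@H](C)O[C@@H](C)C3)nc2)nc1-c1ccc(OC(F)(F)F)cc1`: in an assay on NIH3T3 cells for inhibition of Sonic hedgehog protein (Mus musculus), read by a luciferase reporter, with a stated time of 48 h (a higher number here means a weaker inhibitor, a lower number a stronger inhibitor), compound 1 gives > 500 nM, which is a limit of the assay and not a number.
- compound 2 `Cc1ccccc1C(=O)Nc1ccc(Nc2ncc(C)c(-c3ccc(OC(F)(F)F)cc3)n2)cc1`: compound 2 gives 42.1 nM.
- compound 3 `Cc1cnc(Nc2ccc(C(=O)Nc3c(C)cccc3C)cc2)nc1-c1ccc(OC(F)(F)F)cc1`: compound 3 gives 1.3 nM.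

Among the measured compounds shown here, compound 3 holds the lowest of the two numbers so far; its nearest neighbour is compound 2, the single measured step being a 32-fold lower number from compound 2 to compound 3 (1.51 log units; beyond the scatter). The remaining value, that of compound 1, is only a limit (the limit of > 500 nM in this assay, at which 1 of the 3 values shown sits).

Compound 4 `Cc1cnc(Nc2ccc(C(=O)Nc3c(C)cccc3C)cc2)nc1-c1cccc(OC(F)(F)F)c1` differs from compound 3 by one change, (3-(trifluoromethoxy)phenyl in place of 4-(trifluoromethoxy)phenyl on an aromatic carbon); the site is on an aromatic carbon of a six-membered aromatic ring with 2 nitrogen, next to the ring nitrogen and ortho to a methyl group. For the measured compounds named here, no measured step touches this group: the one step on record, from compound 2 to compound 3, alters the amide linkage instead, and compound 1 stands apart in its other substituent. Going by the values given here, the expectation for compound 4 therefore rests on no direct precedent, and a modest weakening is assumed rather than derived: the step of a 3.8-fold higher number from compound 3 to compound 4 (0.59 log units; beyond the scatter) is expected to be small. Compound 4 is estimated at 5 nM, within 1.5 nM to 20 nM.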

Compound 4, half-maximal inhibitory concentration: 1.2 nM
Compound 4: middle estimate off by 4.2-fold (0.62 log units), on the high side, and the stated range ends above it.
By their numbers in this assay, from the lowest: compounds 4 and 3 (each within the scatter of the next); then compound 2. At a limit, above all of these: compound 1.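

In this assay the change to 3-(trifluoromethoxy)phenyl is a 1.1-fold lower number from compound 3 to compound 4 (0.03 log units; within the scatter), so compounds 3 and 4 cannot be told apart, and with this amide in place, the trifluoromethoxy group can stand on either of these two ring carbons without a change beyond the scatter. Among the compounds shown here, this is the first reading at this position, as the one earlier step, a 32-fold lower number from compound 2 to compound 3 (1.51 log units; beyond the scatter), lies at the amide linkage and says nothing about the aryl group on the shared core. The records shown give no measured reason for the match between compounds 3 and 4.

Open, on these data alone, is whether a plain phenyl, or a trifluoromethyl, nitrile, amine or carboxylic acid in place of the trifluoromethoxy group on this ring, would stay level with compounds 3 and 4. Also open, as far as these compounds go, is whether the two placements would still match with another amide: both are read here only with the (2,6-dimethylphenyl)carbamoyl group, and the ((2-methylphenyl)carbonyl)amino group of compound 2 appears only with 4-(trifluoromethoxy)phenyl.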